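Compound 4: 4-Fluorobenzyl in Place of Benzoyl

The source may report more compounds than this note shows. Statements on the series, on what has been measured and on what is new or still open speak of the compounds shown alone.

Compound 2 `O=C1COCCN1c1ccc(/N=C\c2cn(C(=O)c3ccccc3)c3ccccc23)cc1` gives 86.6% in an ADME assay on BV-2 cells (Mus musculus) for cytotoxicity, read by MTT assay, with a stated time of 48 h, tested at 15 uM; on this read-out lower numbers stand for a stronger effect and higher numbers for a weaker effect at the one concentration tested. Compound 1 `Cc1ccc(S(=O)(=O)n2cc(/C=N\c3ccc(N4CCOCC4=O)cc3)c3ccccc32)cc1` gives 71% in this assay, and compound 3 `O=C1COCCN1c1ccc(/N=C\c2cn(C(=O)c3ccc(Cl)cc3)c3ccccc23)cc1` gives 105%. Compound 2 therefore stands second highest of the three numbers; its nearest neighbour lies a number 15.6 percentage points higher from compound 1 to compound 2 (beyond the scatter) and its furthest a number 18.4 percentage points higher from compound 2 to compound 3 (beyond the scatter), while the full span is a number 34 percentage points higher from compound 1 to compound 3 (beyond the scatter).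

Compound 4 `O=C1COCCN1c1ccc(/N=C\c2cn(Cc3ccc(F)cc3)c3ccccc23)cc1` differs from compound 2 by 4-fluorobenzyl in place of benzoyl on an aromatic nitrogen. Of the measured steps, only a number 15.6 percentage points higher from compound 1 to compound 2 (beyond the scatter) touches the same aromatic nitrogen, and it exchanged one carbonyl-free sulfonyl group for benzoyl rather than removing the carbonyl altogether; a number 18.4 percentage points higher from compound 2 to compound 3 (beyond the scatter) concerns a ring substituent elsewhere. No measured pair shows a benzyl group at this nitrogen, so the bearing of the shown steps is weak. Compound 4 is expected to move no further than a number 6.6 percentage points lower from compound 2 to compound 4 (within the scatter), a step within the scatter. The estimated value of compound 4 in this assay is 80%, ranging from 55% to 105%.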

Compound 4, a percentage reported as activity, at one concentration (the size of the read-out at that concentration, not a potency): 86.1%
Beside the measured number, compound 4's estimate is 6.1 percentage points below it; the measured number falls inside the stated range.
By their numbers in this assay, from the lowest: compound 1; then compounds 4 and 2 (each within the scatter of the next); then compound 3.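

In this assay, the step from a benzoyl to a 4-fluorobenzyl on the aromatic nitrogen is a number 0.5 percentage points lower from compound 2 to compound 4 (within the scatter), so at this position a group without a carbonyl reads the same as one with it. The same group does not match the other two groups at this nitrogen, with a number 18.9 percentage points lower from compound 3 to compound 4 (beyond the scatter) and a number 15.1 percentage points higher from compound 1 to compound 4 (beyond the scatter), so the read-out here does respond to some exchanges at this position, though not to this one. Nothing available explains why this exchange leaves the read-out in place while the other two do not.

On these data alone, it remains open whether a plain benzyl, a short alkyl chain or a longer chain ending in an amine on this nitrogen would read like compound 4. As far as these compounds go, it is also open whether a chloro on the benzyl ring would shift the number as it does on the benzoyl ring.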